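Adding a Methoxy Group to Compound 1

The compounds below may be only part of what the source reports. "The series", "measured", "known", "first", "only" and "open" are said of these compounds alone.

Compound 1 `CC1=CC[C@H](C(C)(C)NC(=S)N/N=C/c2ccc(O)cc2)CC1` stands highest of the numbers shown in a functional assay on PC-3 cells (Homo sapiens) for inhibition, read by sulforhodamine B assay, with a stated time of 48 h (a higher number here means a weaker inhibitor of growth, a lower number a stronger inhibitor of growth), where compound 1 gives 53800 nM. Compound 3 `CC1=CC[C@H](C(C)(C)NC(=S)N/N=C/c2ccccc2Cl)CC1` gives 700 nM in this assay. For compound 2 `CC1=CC[C@H](C(C)(C)NC(=S)N/N=C/c2ccc(F)cc2)CC1` the assay reports only a limit, < 900 nM. Removing the hydroxy group gave an at least 59-fold lower number from compound 1 to compound 2 (1.77 log units; beyond the scatter) and a 77-fold lower number from compound 1 to compound 3 (1.89 log units; beyond the scatter), while a step that the limit leaves unreadable from compound 2 to compound 3 because of the limit of < 900 nM in this assay, at which 1 of the 3 values shown sits. Compound 4 `COc1cc(/C=N/NC(=S)NC(C)(C)[C@H]2CC=C(C)CC2)ccc1O` differs from compound 1 by methoxy in place of hydrogen on an aromatic carbon; the hydroxy group itself is kept. Going by the values given here, neither measured step alters the ring while keeping that hydroxy, so no large step is anticipated, and the expected shift is a 1.8-fold lower number from compound 1 to compound 4 (0.25 log units; within the scatter). Compound 4 is therefore estimated at 30000 nM, between 8000 nM and 90000 nM.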

Compound 4, concentration for total growth inhibition: 8300 nM
Compound 4: the middle estimate sits 3.6-fold (0.56 log units) above what was measured; the measured number falls inside the stated range.
By their numbers in this assay, from the lowest: compound 3; then compound 4; then compound 1.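

Within this assay methoxy in place of hydrogen, ortho to a hydroxy group, gives a 6.5-fold lower number from compound 1 to compound 4 (0.81 log units; beyond the scatter) and so shows that this ring position responds to substitution. The earlier steps shown here all took the hydroxy group away, whereas this one moves the number beyond the scatter with that group kept. Nothing at hand gives a cause for this step.

The compounds shown leave open whether an ethoxy group or an amine at this place would move the number the same way. They also leave open whether methoxy would lower it on a ring without the hydroxy group.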